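Epimer at a Ring Carbon in a Prostaglandin Analogue Series

The source may hold more compounds than are shown below. What is called first, only, known or untested is meant among the compounds shown, and "the series" means these compounds.

Measured compounds:
compound 1, `O=C(O)CC[C@H]1CC[C@@H]2[C@@H](/C=C/[C@@H](O)COc3ccccc3)[C@H](O)C[C@@H]2OC1`, 110 nM in a functional assay on CHO cells for agonist activity at prostaglandin F2-alpha receptor (Homo sapiens), read by fluorescence and calcium flux; on this read-out lower numbers stand for an effect already at smaller amounts and higher numbers for an effect only at larger amounts of compound
compound 2, `O=C(O)CCC[C@@H]1CC[C@@H]2[C@@H](/C=C/[C@@H](O)COc3ccccc3)[C@H](O)C[C@@H]2OC1`, 280 nM

Compound 2 gives the highest of the two numbers in this assay, so its effect sets in only at larger amounts than that of compound 1; the gap between the two lies beyond the usual scatter. Compound 1 and compound 2 differ in more than one place, so their values alone say nothing about any single change.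

Compound 3, `O=C(O)CCC[C@H]1CC[C@@H]2[C@@H](/C=C/[C@@H](O)COc3ccccc3)[C@H](O)C[C@@H]2OC1`, is the next compound to be tested in this assay. Its relation to compound 2 is narrow: the two compounds have the same atoms and bonds and differ only in configuration as drawn: 1 of 7 stereo elements differ; a stereocentre at a saturated ring carbon is drawn R in compound 2 and S in compound 3. Compound 3 shares this configuration with compound 1, while keeping the longer acid chain of compound 2. Because compound 1 gives 110 nM, a modest move toward smaller numbers is expected, though an inverted centre in a flexible fused core can also cut agonism, so the range stays wide. Compound 3 is estimated at 110 nM, between 30 nM and 450 nM, which means an expected step of a 2.5-fold lower number from compound 2 to compound 3 (0.41 log units; beyond the scatter).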

Compound 3, half-maximal effective concentration: 28 nM
Compound 3: the middle estimate sits 3.9-fold (0.59 log units) above what was measured, and the stated range ends above it.
By their numbers in this assay, from the lowest: compound 3; then compound 1; then compound 2.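

The change at this saturated ring carbon, drawn R in compound 2 and S in compound 3, gives a 10-fold lower number from compound 2 to compound 3 (1.00 log units; beyond the scatter) in this assay, and this shift can be assigned to that single centre because nothing else separates the two compounds: the fact that compounds 2 and 3 differ only in the configuration as drawn

With the S configuration kept, carboxymethyl in place of carboxy on a saturated chain carbon, two bonds along the chain from a saturated ring carbon, gives a 3.9-fold lower number from compound 1 to compound 3 (0.59 log units; beyond the scatter), so the longer acid chain goes with the smaller number in this pair. Compound 1 and compound 2 differ in more than one place, so neither step could be read from them.

As far as these compounds go, it remains open how the shorter acid chain behaves with the R configuration at this ring carbon. From the compounds shown here alone, it is also open whether a still longer chain, or an ester or amide in place of the carboxylic acid, would keep the lower number seen with the S configuration.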